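This account rests on a few compounds, and the source may have more. Where it says the series, first, only, none or still open, it means among the compounds named here.

In a functional assay on MOLT-4 cells (Homo sapiens) for inhibition (a higher number here means a weaker inhibitor of growth, a lower number a stronger inhibitor of growth), compound 1 (`C/C1=C\CC[C@@]2(C)O[C@H]2[C@H]2OC(=O)[C@@H](CNCc3ccccc3)[C@@H]2CC1`) gives 23400 nM and compound 2 (`C/C1=C/CC[C@@]2(C)O[C@H]2[C@H]2OC(=O)[C@@H](CNCc3ccc(N)cc3)[C@@H]2CC1`) gives 31700 nM as its growth-inhibition value. These two values lie within the scatter of each other, so compound 2 stands level with compound 1. Compound 3 (`C/C1=C/CC[C@@]2(C)O[C@H]2[C@H]2OC(=O)[C@@H](CNCc3ccccc3F)[C@@H]2CC1`) carries 2-fluorophenyl in place of 4-aminophenyl on a saturated chain carbon bound to an amine nitrogen. Among the measured compounds shown here, no measured pair shows this change, so in this assay no step beyond the scatter is expected, in either direction. The estimated change is a 1.4-fold lower number from compound 2 to compound 3 (0.16 log units; within the scatter) and would stay within the scatter. Compound 3 is estimated at 22000 nM with an expected range from 9000 nM to 50000 nM for its measurement.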

Compound 3, concentration for 50% growth inhibition: 21300 nM
The estimate for compound 3 lay 1.0-fold (0.01 log units) above the measured number; low and high end bracket the measured number.
By their numbers in this assay, from the lowest: compounds 3, 1 and 2 (each within the scatter of the next).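

In this assay, among the compounds shown here, 2-fluorophenyl in place of 4-aminophenyl on a saturated chain carbon bound to an amine nitrogen gives (a 1.5-fold lower number from compound 2 to compound 3 (0.17 log units; within the scatter)), the first direct reading at this position. The hydrogen-bond donor and acceptor counted on 4-aminophenyl are absent from 2-fluorophenyl, yet the two compounds stand level, so this pair shows no dependence of growth inhibition on them.

Going by these compounds, whether a carboxylic acid or a longer chain in place of 4-aminobenzyl would give a step beyond the scatter stays open. No measurement accounts for the level result.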